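From pyridin-2-yl to propyl on the shared core

A few compounds are considered here, and "the series" means these few. Any claim that something is new, unique, unknown or untested is made for them only; others in the source may bear on it.

Measured in a functional assay on MiaPaCa cells (Homo sapiens) for antiproliferative activity, read by sulforhodamine B assay, with a stated time of 48 h; on this read-out lower numbers stand for stronger inhibition of growth and higher numbers for weaker inhibition of growth:
- compound 1 `CCCCCCc1cn(CCCN2C(=O)COc3ccccc32)nn1`: 150 nM
- compound 2 `O=C1COc2ccccc2N1CCCn1cc(-c2ccccn2)nn1`: 5800 nM

Of these two, compound 2 stands highest at 5800 nM, which makes it the weaker inhibitor of growth, while compound 1 gives 150 nM. Compound 3 `CCCc1cn(CCCN2C(=O)COc3ccccc32)nn1` has not yet been measured. It keeps the shared core and departs from compound 2 in one place: propyl in place of pyridin-2-yl on an aromatic carbon.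

Among the measured compounds shown here, one measured step bears on this change. It is a 39-fold higher number from compound 1 to compound 2 (1.59 log units; beyond the scatter), large and beyond the scatter, and it replaced hexyl with pyridin-2-yl. For the measured compounds named here, compound 3 reverses the ring-for-chain part of that step, but its propyl chain is shorter than the hexyl of compound 1, and no measured compound shows what shortening the chain does. Only part of the large step is therefore expected to be recovered, towards a lower number. The expected change is a 6.4-fold lower number from compound 2 to compound 3 (0.81 log units; beyond the scatter). For compound 3 the estimated value is 900 nM, with an expected range from 250 nM to 3000 nM.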

Compound 3, concentration for 50% growth inhibition: 2600 nM
The estimate for compound 3 lay 2.9-fold (0.46 log units) below the measured number; the measured number falls inside the stated range.
By their numbers in this assay, from the lowest: compound 1; then compound 3; then compound 2.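

In this assay, putting propyl in place of pyridin-2-yl on this aromatic carbon gives a 2.2-fold lower number from compound 2 to compound 3 (0.35 log units; beyond the scatter), so a modest gain is all that comes from exchanging the ring for a short open chain. The larger change lies along the chain itself: shortening hexyl to propyl gives a 17-fold higher number from compound 1 to compound 3 (1.24 log units; beyond the scatter), which shows that an open chain at this position does not alone bring the low number of compound 1 and that the length of the chain matters strongly across these compounds. Nothing available explains either step, and no measurement beyond the growth-inhibition numbers bears on them.

The compounds shown leave open how the number changes between propyl and hexyl, as with butyl or pentyl, and whether it keeps falling with a longer chain such as octyl. They also leave open whether the pyridin-2-yl result belongs to aromatic rings generally, which a phenyl group at this position would test, and whether a hexyl chain ending in an amine or a carboxylic acid would keep the number of compound 1.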